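Replacing fluoro with methylsulfanyl in a growth inhibitor

The source may hold more compounds than are shown below. What is called first, only, known or untested is meant among the compounds shown, and "the series" means these compounds.

Compound 1 `CSc1ccc(C2=C(c3ccc(OCC4CO4)cc3)C(=O)N3CCCC3C2)cc1` gives 90 nM
Compound 2 `CSc1ccc(C2=C(c3ccc(F)cc3)C(=O)N3CCCC3C2)cc1` gives 500 nM

For the measured compounds named here, in a functional assay on SW-620 cells (Homo sapiens) for cytotoxicity (a lower number here means a stronger inhibitor of growth, a higher number a weaker inhibitor of growth), compound 2 gives 500 nM and holds the higher of the two numbers so far. Compound 3 `CSc1ccc(C2=C(c3ccc(SC)cc3)C(=O)N3CCCC3C2)cc1` has methylsulfanyl in place of fluoro on an aromatic carbon. Going by the values given here, one measured step bears on this change: a 5.6-fold higher number from compound 1 to compound 2 (0.74 log units; beyond the scatter) when fluoro replaced (oxiran-2-yl)methoxy at this place. That single modest step is thin evidence, but it suggests that replacing fluoro may lower the number slightly. The expected change in this assay is small, with a 2.3-fold lower number from compound 2 to compound 3 (0.36 log units; beyond the scatter) as the estimate, and it may not clear the usual scatter. Compound 3 is expected at 220 nM with 70 nM to 700 nM as the estimated range.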

Compound 3, concentration for 50% growth inhibition: 7000 nM
Compound 3: the middle estimate sits 32-fold (1.50 log units) below what was measured; the measured number lies above the stated range.
By their numbers in this assay, from the lowest: compound 1; then compound 2; then compound 3.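

In this assay, this position proves highly sensitive to its group: methylsulfanyl in place of fluoro gives a 14-fold higher number from compound 2 to compound 3 (1.15 log units; beyond the scatter), a larger step than the earlier one, though only one heavy atom is added. Methylsulfanyl in place of (oxiran-2-yl)methoxy gives a 78-fold higher number from compound 1 to compound 3 (1.89 log units; beyond the scatter), so the three groups at this place span a wide range of growth inhibition. No measurement here accounts for the loss.

As far as these compounds go, whether an amine, a carboxylic acid or a longer chain at this place would fall nearer the lowest or the highest number remains open.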